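A few compounds are considered here, and "the series" means these few. Any claim that something is new, unique, unknown or untested is made for them only; others in the source may bear on it.

Values so far in a functional assay on HeLa cells (Homo sapiens) for inhibition, read by MTT assay, with a stated time of 48 h (a lower number here means a stronger inhibitor, a higher number a weaker inhibitor), are these:
compound 1 `O=S(=O)(c1ccccc1)c1c(OCCCCCCO)no[n+]1[O-]` gives "not determined" (no result reported)
compound 2 `O=C(CCCOc1no[n+]([O-])c1S(=O)(=O)c1ccccc1)NO` gives 4790 nM
compound 3 `O=C(CCCCCCOc1no[n+]([O-])c1S(=O)(=O)c1ccccc1)NO` gives 4090 nM

For the measured compounds named here, compound 2 and compound 3 hold the only two numbers, and they lie within the scatter of each other. Compound 4 `CC(C)(COc1no[n+]([O-])c1S(=O)(=O)c1ccccc1)C(=O)NO` carries 1-(hydroxycarbamoyl)-1-methylethyl in place of 2-(hydroxycarbamoyl)ethyl on a saturated chain carbon bound to an oxygen on an aromatic ring. Going by the values given here, no measured step covers this kind of change. The nearest evidence is a 1.2-fold lower number from compound 2 to compound 3 (0.07 log units; within the scatter) and it stays within the scatter, so no shift beyond the scatter is expected in this assay here. The expected step is a 1.1-fold lower number from compound 2 to compound 4 (0.03 log units; within the scatter) and it is a weakly supported one. Compound 4 is estimated at 4500 nM (range 1800 nM to 11000 nM).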

Compound 4, half-maximal inhibitory concentration: 6360 nM
The estimate for compound 4 lay 1.4-fold (0.15 log units) below the measured number; the measured number falls inside the stated range.
By their numbers in this assay, from the lowest: compounds 3, 2 and 4 (each within the scatter of the next).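

In this assay, 1-(hydroxycarbamoyl)-1-methylethyl in place of 2-(hydroxycarbamoyl)ethyl on a saturated chain carbon bound to an oxygen on an aromatic ring gives a 1.3-fold higher number from compound 2 to compound 4 (0.12 log units; within the scatter). For the compounds shown here, the earlier step covered only chain length, so this is the first sign that a branched group at this position leaves the number within the scatter. No available evidence bears on this result.

Open, on these data alone, is whether a carboxylic acid or an amine in place of the hydroxycarbamoyl group would move the number beyond the scatter. Also open, as far as these compounds go, is whether a larger branch, such as two ethyl groups in place of the two methyl groups, would do so.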